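The source may hold more compounds than are shown below. What is called first, only, known or untested is meant among the compounds shown, and "the series" means these compounds.

Working notes on the series.

The set is read in a functional assay on HEK293 cells for agonist activity at Glucose-dependent insulinotropic receptor (Homo sapiens), read by cAMP accumulation, with a stated time of 30 min; on this read-out lower numbers stand for an effect already at smaller amounts and higher numbers for an effect only at larger amounts of compound. Compound 1, `CC1(OC(=O)N2C[C@H]3COC[C@@H](C2)[C@@H]3Oc2ncnc(Nc3ccccc3F)c2F)CC1`, gives 6 nM in this assay. Compound 2, `N#Cc1ccc(Nc2ncnc(OC3C4COCC3CN(C(=O)OC3CCC3)C4)c2F)c(Cl)c1`, gives 10 nM in this assay, and the gap between compound 1 and compound 2 lies within the scatter of repeated measurements, so the two are not separable on these numbers. Compound 3, `COc1c(Nc2ccc(S(C)(=O)=O)cc2F)ncnc1OC1C[C@@H]2COC[C@@H](C1)N2C(=O)OC1(C)CC1`, gives 97 nM in this assay, a number clearly higher than that of compound 1 and beyond the scatter. Compound 1 thus carries the lowest of the three numbers, but it is not set apart from compound 2. Within the data shown here, no single-point step between measured compounds is available, so no measured step size can be quoted.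

Compound 4, `CC1(OC(=O)N2C[C@H]3COC[C@@H](C2)[C@@H]3Oc2ncnc(Nc3c(F)cccc3F)c2F)CC1`, has not yet been measured in this assay. It differs from compound 1 by the change (fluoro in place of hydrogen on an aromatic carbon), that is, 2-fluorophenyl to 2,6-difluorophenyl on the anilino part of the shared core. With no measured step of this kind in the series, the expectation rests on the change being one fluorine on an aromatic carbon: the step of a 1.2-fold lower number from compound 1 to compound 4 (0.08 log units; within the scatter) is expected to be small, in either direction, and not beyond the scatter. Compound 4 is therefore estimated at 5 nM in this assay, with a range from 1.5 nM to 17 nM.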

Compound 4, half-maximal effective concentration: 13 nM
The estimate for compound 4 lay 2.6-fold (0.41 log units) below the measured number; the measured number falls inside the stated range.
By their numbers in this assay, from the lowest: compounds 1, 2 and 4 (each within the scatter of the next, the first and the last beyond it); then compound 3.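

Fluoro in place of hydrogen on the anilino part, 2-fluorophenyl to 2,6-difluorophenyl, gives the first single-place step of the series: in this assay it reads a 2.2-fold higher number from compound 1 to compound 4 (0.34 log units; beyond the scatter). This aromatic carbon, ortho to a large group and meta to a fluoro group, is therefore not silent to a change of one heavy atom: the added fluoro goes with a modest rise in the number, and compound 4 stands at 13 nM. Nothing measured on these compounds speaks to the origin of this step, so it stands as an observation only.

On these data alone, whether the rise belongs to fluoro itself or would follow any group at this carbon stays open, and a chloro, a hydroxyl, an amino group or an ethyl chain in the same place would begin to separate those readings. Also open, as far as these compounds go, is whether the same change would give a step of similar size on the aniline rings of compound 2 and compound 3, whose cores and substituents differ from that of compound 1 in more than one place.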